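The source may hold more compounds than are shown below. What is called first, only, known or untested is meant among the compounds shown, and "the series" means these compounds.

Series notes on an ADME assay on a cell-free system (plasma, Rattus norvegicus) for metabolic stability; on this read-out higher numbers stand for a longer-lived compound and lower numbers for a shorter-lived compound.

Within the data shown here, compound 2 `Cc1ccc(/N=N/c2sc(N3Nc4onc(-c5ccccc5)c4C3c3ccc(Cl)cc3)nc2C)cc1` has the highest of the three numbers measured so far: in this assay compound 2 gives 5.72 h. Compound 1 `Cc1nc(N2Nc3onc(-c4ccccc4)c3C2c2ccc(Cl)cc2)sc1/N=N/c1ccccc1` lies nearest, and in this assay compound 1 gives 4.42 h; compound 3 `COc1ccc(/N=N/c2sc(N3Nc4onc(-c5ccccc5)c4C3c3ccc(Cl)cc3)nc2C)cc1` lies furthest, and in this assay compound 3 gives 3.9 h. All three differences are within the scatter: a 1.3-fold higher number from compound 1 to compound 2 (0.11 log units; within the scatter), a 1.1-fold lower number from compound 1 to compound 3 (0.05 log units; within the scatter) and a 1.5-fold lower number from compound 2 to compound 3 (0.17 log units; within the scatter), so no order among compounds 1, 2 and 3 can be read from them.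

Compound 4 `Cc1csc(N2Nc3onc(-c4ccccc4)c3C2c2ccc(Cl)cc2)n1` has not been measured. It differs from compound 2 by a hydrogen atom in place of a group of 9 heavy atoms (7 carbon, 2 nitrogen; one six-membered aromatic ring of carbon only), on an aromatic carbon. The group that leaves sits on an aromatic carbon of the five-membered aromatic ring, next to the ring sulfur and next to the ring atom that bears a methyl group.

Among the measured compounds shown here, none of the measured steps bears on this change: the steps from compound 1 to compound 2, from compound 1 to compound 3 and from compound 2 to compound 3 all alter only the six-membered aromatic ring of carbon only, which is itself removed here, and all were within the scatter. There is therefore no basis from the measured compounds for a direction, and the step from compound 2 to compound 4 is expected to be a 1.3-fold lower number from compound 2 to compound 4 (0.10 log units; within the scatter), with wide uncertainty. Compound 4 is estimated at 4.5 h, in a range from 1.5 h to 13 h.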

Compound 4, half-life: 5.72 h
For compound 4 the middle estimate is 1.3-fold (0.10 log units) below the measured one; the range from low to high includes it.
By their numbers in this assay, from the lowest: compounds 3, 1, 2 and 4 (each within the scatter of the next).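

Among these compounds, replacing the whole group of 9 heavy atoms (7 carbon, 2 nitrogen; one six-membered aromatic ring of carbon only) with a hydrogen atom tests this position directly, whereas the earlier steps altered only that group's outer ring: in this assay the change gives no change at the digits printed from compound 2 to compound 4 (within the scatter), and the related replacements give a 1.3-fold higher number from compound 1 to compound 4 (0.11 log units; within the scatter) and a 1.5-fold higher number from compound 3 to compound 4 (0.17 log units; within the scatter). None of these steps leaves the scatter, so on the aromatic carbon next to the ring sulfur, neither the unsubstituted group of compound 1 nor its methyl and methoxy forms in compound 2 and compound 3 can be told apart from a hydrogen atom by this read-out. No measurement shown accounts for this outcome.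

Still open, going by these compounds, is whether any substituent on this carbon can move the half-life beyond the scatter, and a carboxylic acid, an amine or a longer chain there would test this. Also open, on these data alone, is how the read-out responds to changes in the shared core, including replacement of the methyl group on the neighbouring ring atom.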